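The source may hold more compounds than are shown below. What is called first, only, known or untested is meant among the compounds shown, and "the series" means these compounds.

The measured compounds and their numbers:

Compound 1, `CCN(CC)c1ccc2cc(C(=O)c3ccc(N4CCN(C(=O)COc5ccc(Cl)cc5Cl)CC4)cc3)oc2c1`, gives 6170 nM.
Compound 2, `CCN(CC)c1ccc2cc(C(=O)c3ccc(N4CCN(S(=O)(=O)c5ccc(Br)cc5)CC4)cc3)oc2c1`, reports only a limit of the assay, > 40000 nM.
Compound 3, `CCN(CC)c1ccc2cc(C(=O)c3ccc(N4CCN(S(=O)(=O)c5ccc(C(F)(F)F)cc5)CC4)cc3)oc2c1`, gives 170 nM.

In a functional assay on SGC-7901 cells (Homo sapiens) for cytotoxicity, read by MTT assay, with a stated time of 48 h (a lower number here means a stronger inhibitor, a higher number a weaker inhibitor), compound 3 holds the lowest number of the two numbers given, with compound 1 standing a good deal higher at 6170 nM. Compound 4, `CCN(CC)c1ccc2cc(C(=O)c3ccc(N4CCN(S(=O)(=O)c5ccc(C)cc5)CC4)cc3)oc2c1`, is the compound still to be measured. It differs from compound 3 in one place: methyl in place of trifluoromethyl on an aromatic carbon.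

Two measured steps are available. The first, an at least 6.4-fold higher number from compound 1 to compound 2 (0.81 log units; beyond the scatter), changes the whole group on the ring nitrogen. The second, an at least 230-fold lower number from compound 2 to compound 3 (2.37 log units; beyond the scatter), swaps only the group on the same aromatic carbon that compound 4 alters, and it was large. That step shows the group at this position can move the number a long way, though it does not show where methyl falls between bromo and trifluoromethyl. A weaker result than compound 3 is expected, with wide uncertainty. Compound 4 is therefore estimated at 3000 nM, within 400 nM to 30000 nM, a step of an 18-fold higher number from compound 3 to compound 4 (1.25 log units; beyond the scatter).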

Compound 4, half-maximal inhibitory concentration: > 40000 nM
Compound 4 gave a limit, no number (the forecaster's own chance of this, stated with the estimate: 25%); middle value at least 13-fold (1.12 log units) from the limit.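

In this assay, compound 3 gives a measured number, but methyl in place of trifluoromethyl loses it (an at least 230-fold higher number from compound 3 to compound 4 (2.37 log units; beyond the scatter)). The earlier large step therefore was not special to bromo: bromo and methyl on this aromatic carbon both end at a limit of the assay, and of these three sulfonyl compounds only the 4-(trifluoromethyl)phenyl one gives a number. Compound 4 also falls behind compound 1, which carries the ((2,4-dichlorophenoxy)methyl)carbonyl group on the ring nitrogen (an at least 6.4-fold higher number from compound 1 to compound 4 (0.81 log units; beyond the scatter)), so the sulfonyl link alone does not secure a low number.

As far as these compounds go, whether a nitrile, a methoxy group or an amine on this carbon would give a number stays open. The step between compound 2 and compound 4 cannot be read, since each gives only a limit: the limit of > 40000 nM in this assay, at which 2 of the 4 values shown sit.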